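Isopropoxycarbonyl for tert-butoxycarbonyl: notes on compound 3

The source may report more compounds than this note shows. Statements on the series, on what has been measured and on what is new or still open speak of the compounds shown alone.

Measured in a physicochemical assay for solubility, in simulated intestinal fluid (on this read-out lower numbers stand for lower solubility and higher numbers for higher solubility), so far
compound 1 `CC(C)(C)OC(=O)N1CCC(CCCCCOc2ccc(S(C)(=O)=O)cc2)CC1` gives 15900 nM
compound 2 `CN(C)C(=O)c1ccc(OCCCCCC2CCN(C(=O)OC(C)(C)C)CC2)cc1` gives 74200 nM

Compound 2 at 74200 nM holds the higher of the two numbers, and the gap to compound 1 lies beyond the scatter. Compound 3 `CC(C)OC(=O)N1CCC(CCCCCOc2ccc(C(=O)N(C)C)cc2)CC1` differs from compound 2 by hydrogen in place of methyl on a saturated chain carbon bound to an oxygen next to a carbonyl group and two saturated chain carbons and so reads as tert-butoxycarbonyl to isopropoxycarbonyl. Among the measured compounds shown here, the only measured step is a 4.7-fold higher number from compound 1 to compound 2 (0.67 log units; beyond the scatter) and it is modest. That step is dimethylcarbamoyl in place of methylsulfonyl on an aromatic carbon, at another place in the molecule, so it bears on the present change only indirectly. For the measured compounds named here, no measured pair tests hydrogen in place of methyl at this carbon. On these data alone, a step beyond the scatter is therefore not expected in this assay and the direction remains open, with a slight rise as the working guess. The estimated step is a 1.1-fold higher number from compound 2 to compound 3 (0.06 log units; within the scatter) and it is expected to stay small. For compound 3 the estimate is 85000 nM with an expected range from 40000 nM to 170000 nM around it.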

Compound 3, solubility: 222000 nM
Compound 3: middle estimate off by 2.6-fold (0.42 log units), on the low side, outside the stated range (above it).
By their numbers in this assay, from the lowest: compound 1; then compound 2; then compound 3.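

In this assay, this position turns out not to be silent: tert-butoxycarbonyl to isopropoxycarbonyl gives a 3.0-fold higher number from compound 2 to compound 3 (0.48 log units; beyond the scatter). The change removes a methyl, 1 heavy atom, with no ring, no hydrogen-bond donor or acceptor and no net charge among what leaves, and that is enough to carry the number beyond the scatter, so this end of the molecule counts as a place where the read-out responds, alongside the aromatic carbon behind a 4.7-fold higher number from compound 1 to compound 2 (0.67 log units; beyond the scatter). No measurement at hand bears on why the number moves at this carbon.

Among the compounds shown here, open is whether the step carries over to the methylsulfonyl partner, as the one pair at this position has dimethylcarbamoyl on the aromatic carbon, so a single pair stands for the change and its size on another background cannot be read from it. Also open, on these data alone, is whether the number keeps rising along the series with ethoxycarbonyl or methoxycarbonyl in place of isopropoxycarbonyl, or whether it turns with an acetyl group or a longer chain on the same oxygen-bearing carbon.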